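Triarylmethane series: replacing the amine side chain with an acid

The source may hold more compounds than are shown below. What is called first, only, known or untested is meant among the compounds shown, and "the series" means these compounds.

Compound 2 `COc1ccc(C(c2ccc(OC(C)CN(C)C)cc2)c2cccc3ccccc23)c(OC)c1OC` carries a 1-((dimethylamino)methyl)ethoxy side chain on one aryl ring. In a functional assay on HCT-116 cells (Homo sapiens) for inhibition, read by sulforhodamine B assay, with a stated time of 48 h (on this read-out lower numbers stand for stronger inhibition and higher numbers for weaker inhibition), compound 2 gives 8410 nM. Within the data shown here, this is the only numerical value in hand for the series; the one other entry is a limit. Compound 1 `CCOC(=O)C(C)C(O)(c1ccc(OC)c(OC)c1OC)c1cccc2ccccc12`, a hydroxy ester analogue, gives only a limit in this assay, > 20000 nM, so no number is known for it. That the limit of > 20000 nM in this assay, at which 1 of the 2 values shown sits, marks where one of the two entries sits, and compound 2 is therefore not placed against any measured neighbour.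

Compound 3 `COc1ccc(C(c2ccc(OCC(=O)O)cc2)c2cccc3ccccc23)c(OC)c1OC` is the unmeasured analogue. Against compound 2 the change is carboxymethyl in place of 1-((dimethylamino)methyl)ethyl on an oxygen on an aromatic ring.

Among the measured compounds shown here, no measured step across this kind of exchange exists, so the size of the step from compound 2 to compound 3 in this assay cannot be read from data. The expectation is a step toward weaker inhibition, a 2.4-fold higher number from compound 2 to compound 3 (0.38 log units; beyond the scatter), possibly reaching the same limit as compound 1. Compound 3 is estimated at 20000 nM, with a range from 6000 nM to 60000 nM and a substantial chance that only a limit is reported.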

Compound 3, half-maximal inhibitory concentration: 5020 nM
Beside the measured number, compound 3's estimate is 4.0-fold (0.60 log units) above it; the whole stated range lies above it.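

In this assay, exchanging 1-((dimethylamino)methyl)ethyl for carboxymethyl on an oxygen on an aromatic ring gives a 1.7-fold lower number from compound 2 to compound 3 (0.22 log units; within the scatter), so this pair cannot be told apart on this read-out. Among these compounds, this is the first measured step at this position, and it shows that the side chain bearing the dimethylamino group is not required for a measured number in this assay, since the carboxymethyl side chain of compound 3 also yields a number rather than a limit. Compound 1 remains the only entry given as a limit and not a number: the limit of > 20000 nM in this assay, at which 1 of the 3 values shown sits.

On these data alone, whether a longer chain ending in a carboxylic acid, a chain ending in a primary amide or a plain methyl group on this oxygen would move the number beyond the scatter stays open. This single pair also cannot tell whether the side chain at this position contributes to the inhibition at all, or why two such different groups give values within the scatter of each other.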